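This account rests on a few compounds, and the source may have more. Where it says the series, first, only, none or still open, it means among the compounds named here.

Measured so far:
compound 1 `CCN(CC)Cc1ccc2nc(NC(=O)N/N=C/c3c[nH]c4ccccc34)sc2c1` — 3140 nM
compound 2 `Cc1ccc(Cn2cc(/C=N/NC(=O)Nc3nc4ccc(CN(C)C)cc4s3)c3ccccc32)cc1` — 200 nM
compound 3 `Cc1ccc(Cn2cc(/C=N/NC(=O)Nc3nc4ccc(CN5CCC(C)CC5)cc4s3)c3ccccc32)cc1` — 410 nM

In a functional assay on NCI-H460 cells (Homo sapiens) for cytotoxicity, read by MTT assay, with a stated time of 72 h (on this read-out higher numbers stand for weaker inhibition and lower numbers for stronger inhibition), compound 2 gives the lowest of the three numbers; compound 3 sits nearest, with a 2.1-fold higher number from compound 2 to compound 3 (0.31 log units; beyond the scatter), and compound 1 lies furthest away. Compound 4 `CN(C)Cc1ccc2nc(NC(=O)N/N=C/c3c[nH]c4ccccc34)sc2c1` is not yet measured in this assay. It differs from compound 2 by hydrogen in place of 4-methylbenzyl on an aromatic nitrogen.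

Among the compounds with values here, no measured step isolates this change. Within the data shown here, the only single-point step, from compound 2 to compound 3, concerns the amine on the saturated chain carbon and is modest in size, so it bears on the series only indirectly. Compound 1 carries hydrogen on the aromatic nitrogen, as compound 4 does, but also a different amine, so its gap to compound 2 combines two changes; that gap is large. Taking the amine change as modest by analogy with the step from compound 2 to compound 3, most of that gap is expected to go with the benzyl-to-hydrogen change, so a sizeable increase in the number, a 10-fold higher number from compound 2 to compound 4 (1.00 log units; beyond the scatter), is expected for compound 4. The estimate for compound 4 in this assay is 2000 nM, within 600 nM to 6000 nM.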

Compound 4, half-maximal inhibitory concentration: 2550 nM
For compound 4 the middle estimate is 1.3-fold (0.11 log units) below the measured one; measured number inside the range.
By their numbers in this assay, from the lowest: compound 2; then compound 3; then compounds 4 and 1 (each within the scatter of the next).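

Hydrogen in place of 4-methylbenzyl on the aromatic nitrogen, read on its own in this assay, is a large change (a 13-fold higher number from compound 2 to compound 4 (1.11 log units; beyond the scatter)), and it outweighs the modest amine step (a 2.1-fold higher number from compound 2 to compound 3 (0.31 log units; beyond the scatter)). With hydrogen at this nitrogen, dimethylamino in place of diethylamino gives a step within the scatter (a 1.2-fold lower number from compound 1 to compound 4 (0.09 log units; within the scatter)), so compound 1 and compound 4 cannot be told apart by their amines. No measurement in hand accounts for the size of the benzyl step.

The compounds shown leave open whether a small group on this nitrogen, such as methyl, would carry any of the effect of 4-methylbenzyl, or whether the aromatic ring is needed. Also open, going by these compounds, is whether unsubstituted benzyl or 4-fluorobenzyl would match compound 2 in this assay.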